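The source may hold more compounds than are shown below. What is called first, only, known or untested is meant among the compounds shown, and "the series" means these compounds.

Compound 1 `C=CS(=O)(=O)N1CCN(c2ccn3ncc(-c4ccccc4)c3n2)CC1`: 38300 nM
Compound 2 `C=CS(=O)(=O)N1CCN(c2ncnc3sc(-c4ccc(C(F)(F)F)cc4)cc23)CC1`: 6410 nM

In a functional assay on MDA-MB-231 cells (Homo sapiens) for antiproliferative activity, read by MTT assay, with a stated time of 48 h (a lower number here means a stronger inhibitor, a higher number a weaker inhibitor), compound 2 gives 6410 nM, the lower of the two numbers, and the gap to compound 1 at 38300 nM lies beyond the scatter. These two compounds differ in more than one place, so their values offer no direct guide to a single change.

Compound 3 `C=CS(=O)(=O)N1CCN(c2ncnc3sc(-c4cccc5ccccc45)cc23)CC1` has not yet been measured in this assay. It keeps the rest of compound 2 and carries naphthalen-1-yl in place of 4-(trifluoromethyl)phenyl on an aromatic carbon of the five-membered aromatic ring with 1 sulfur, next to the ring sulfur: naphthalen-1-yl in place of 4-(trifluoromethyl)phenyl on an aromatic carbon.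

Within the data shown here, no measured pair shows what this exchange does, so the expectation is anchored on compound 2 at 6410 nM. A small step is expected, most likely within the scatter, with no firm direction and only a slight lean towards a lower number. The expected step is a 1.2-fold lower number from compound 2 to compound 3 (0.07 log units; within the scatter). For compound 3 the estimated value is 5500 nM, with an expected range from 2000 nM to 15000 nM.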

Compound 3, half-maximal inhibitory concentration: 23700 nM
Compound 3: the middle estimate sits 4.3-fold (0.63 log units) below what was measured; the measured number lies above the stated range.
By their numbers in this assay, from the lowest: compound 2; then compounds 3 and 1 (each within the scatter of the next).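

In this assay, among these compounds, the exchange of 4-(trifluoromethyl)phenyl for naphthalen-1-yl gives a 3.7-fold higher number from compound 2 to compound 3 (0.57 log units; beyond the scatter), the first comparison here that isolates a single change, and it moves towards the weaker inhibitor. This shows that the aromatic carbon on the five-membered aromatic ring with 1 sulfur, next to the ring sulfur, is not indifferent to which aryl group it carries, even though the two groups match in heavy atom count, with no hydrogen-bond donors or acceptors and no net charge on either, so these shared counts do not settle the value. Nothing available explains why the two groups differ in this way.

The compounds shown leave open how this carbon responds to groups of a different kind, such as a simple methyl group or a phenyl ring bearing an amine or a carboxylic acid. Going by these compounds, it also remains open whether the same exchange would give a step of similar size and direction on the core of compound 1, which differs from compound 2 in more than one place.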